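A few compounds are considered here, and "the series" means these few. Any claim that something is new, unique, unknown or untested is made for them only; others in the source may bear on it.

For the measured compounds named here, in a functional assay on A549 cells (Homo sapiens) for cytotoxicity, read by MTT assay, with a stated time of 48 h (a lower number here means a stronger inhibitor, a higher number a weaker inhibitor), two compounds built on a shared core have numbers so far. Compound 1 `O=C1Nc2ccccc2C1(c1c[nH]c2ccc([N+](=O)[O-])cc12)c1c[nH]c2ccc([N+](=O)[O-])cc12` gives 7900 nM, and compound 2 `O=C1Nc2ccccc2C1(c1c(-c2ccccc2)[nH]c2ccccc12)c1c(-c2ccccc2)[nH]c2ccccc12` gives 8910 nM. These two values lie within the usual scatter of repeated measurements, so compound 2 cannot be told apart from compound 1 here, even though the groups attached to their shared core differ.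

Compound 3 `O=C1Nc2ccc(Cl)cc2C1(c1c(-c2ccccc2)[nH]c2ccccc12)c1c(-c2ccccc2)[nH]c2ccccc12` keeps all of compound 2 except for one change: chloro in place of hydrogen on an aromatic carbon. In words, this is chloro in place of hydrogen on an aromatic carbon. Going by the values given here, no measured pair of compounds shows what a single change of this kind does, so the data offer no direct guide. In this assay, a small step toward a lower number is expected, and it may well stay within the scatter. The estimated change is a 1.5-fold lower number from compound 2 to compound 3 (0.17 log units; within the scatter). For compound 3, the expected value is 6000 nM, with an estimated range from 2500 nM to 14000 nM.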

Compound 3, half-maximal inhibitory concentration: > 100000 nM
Compound 3 was reported as a limit (the forecaster's own chance of this, stated with the estimate: 5%); middle value at least 16-fold (1.22 log units) away from the limit.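

In this assay, chloro in place of hydrogen on an aromatic carbon gives an at least 11-fold higher number from compound 2 to compound 3 (1.05 log units; beyond the scatter), a large step beyond the scatter. Compound 3 gives > 100000 nM, which is a limit of the assay and not a number: the limit of > 100000 nM in this assay, at which 1 of the 3 values shown sits.

Compound 1 and compound 2 differ in more than one place, so they could not show what one change does, whereas this pair shows that this position, on the six-membered aromatic ring, meta to a fused ring and para to a fused ring, is far from indifferent, as a single heavy atom here separates a measurable value from a limit.

Going by these compounds, what stays open is whether this result belongs to chloro alone or to any group at this position, a question that a fluoro, a methyl or an amine in the same place would help to settle. On these data alone, this is also a single pair, so it remains unknown whether the same change would have a similar effect with the groups of compound 1 on the shared core.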